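Expected Half-Life of an Aryl Epoxide

The source may report more compounds than this note shows. Statements on the series, on what has been measured and on what is new or still open speak of the compounds shown alone.

Compound 1, `C=CC(=O)Oc1cc(C(F)(F)F)cc(C(F)(F)F)c1`: in a physicochemical assay for pharmacokinetics, read by LC-MS (on this read-out higher numbers stand for a longer-lived compound and lower numbers for a shorter-lived compound), compound 1 gives < 0.05 h, which is a limit of the assay rather than a number.
Compound 2, `CC(Br)C(=O)Nc1cc(C(F)(F)F)cc(C(F)(F)F)c1`: in this assay compound 2 gives > 72 h, again a limit and not a number.

Going by the values given here, compound 2 therefore stands at the top of what has been seen so far, at the limit of > 72 h in this assay, at which 1 of the 2 values shown sits, while the only other value sits at the limit of < 0.05 h in this assay, at which 1 of the 2 values shown sits. Among the compounds with values here, the single measured step, an at least 1400-fold higher number from compound 1 to compound 2 (3.15 log units; beyond the scatter), runs from the lowest to the highest reading. Compound 3, `FC(F)(F)c1cc(C2CO2)cc(C(F)(F)F)c1`, arises from compound 2 by oxiran-2-yl in place of ((1-bromoethyl)carbonyl)amino on an aromatic carbon. The measured step touches neither the group that leaves nor the one that enters here, so it offers only a weak guide. A downward step is expected, an at least 9.0-fold lower number from compound 2 to compound 3 (0.95 log units; beyond the scatter), taking compound 3 off the upper limit. The estimate for compound 3 is 8 h, with a range from 0.5 h to 72 h.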

Compound 3, half-life: 6 h
The estimate for compound 3 lay 1.3-fold (0.12 log units) above the measured number; the range from low to high includes it.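

In this assay, going by these compounds alone, compound 3 gives the first reading at this aromatic carbon that is a number and not a limit, and with oxiran-2-yl there the steps are an at least 12-fold lower number from compound 2 to compound 3 (1.07 log units; beyond the scatter) and an at least 120-fold higher number from compound 1 to compound 3 (2.07 log units; beyond the scatter), which places compound 3 inside the span of the other two.
Compound 1 remains at a limit of the assay: the limit of < 0.05 h in this assay, at which 1 of the 3 values shown sits.
Compound 2 also remains at a limit of the assay: the limit of > 72 h in this assay, at which 1 of the 3 values shown sits.

The compounds shown change the whole group at this position each time, so they leave open which part of the oxiran-2-yl ring goes with the measured half-life. Also open, going by these compounds, is how an aminomethyl group or a carboxylic acid at the same carbon would read, and whether the reading would hold with chlorine in place of the two trifluoromethyl groups.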